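The source may hold more compounds than are shown below. What is called first, only, known or untested is meant among the compounds shown, and "the series" means these compounds.

The compounds measured in a functional assay on EC9706 cells (Homo sapiens) for cytotoxicity, read by MTT assay, with a stated time of 72 h (on this read-out higher numbers stand for weaker inhibition and lower numbers for stronger inhibition), are these:

compound 1 `NC(=O)N1CCN(C(=S)SCc2cn(Cc3ccc(F)cc3)nn2)CC1` gives 62700 nM
compound 2 `CC(C)NC(=O)N1CCN(C(=S)SCc2cn(Cc3ccc(F)cc3)nn2)CC1` gives 12200 nM
compound 3 `O=C(NC1CCCCC1)N1CCN(C(=S)SCc2cn(Cc3ccc(F)cc3)nn2)CC1` reaches only a limit of the assay, > 128000 nM

Of the two numbers that are known, compound 1 stands highest; the nearest is compound 2, reached by a 5.1-fold lower number from compound 1 to compound 2 (0.71 log units; beyond the scatter). Compound 3 sits at the limit of > 128000 nM in this assay, at which 1 of the 3 values shown sits. Its steps from the others are an at least 2.0-fold higher number from compound 1 to compound 3 (0.30 log units; that floor lies within the scatter) and an at least 10-fold higher number from compound 2 to compound 3 (1.02 log units; beyond the scatter). All three measured steps alter the group on the amide-type nitrogen of the shared core and leave the rest of the molecule untouched.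

Compound 4 `COc1ccc(Cn2cc(CSC(=S)N3CCN(C(N)=O)CC3)nn2)cc1` keeps that nitrogen as in compound 1 and differs from it at a different place: methoxy in place of fluoro on an aromatic carbon. Among the measured compounds shown here, no measured step changes anything on this aromatic ring, so none of them bears directly on the change from compound 1 to compound 4. Without a comparable step to lean on, compound 4 is expected to stay close to compound 1, with a 1.0-fold higher number from compound 1 to compound 4 (0.00 log units; within the scatter) and no step beyond the scatter. Compound 4 is therefore estimated at 63000 nM, with a range from 20000 nM to 160000 nM.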

Compound 4, half-maximal inhibitory concentration: > 128000 nM
Compound 4 ended at the assay's limit; the forecaster's own chance of this, stated with the estimate: 25%; middle value at least 2.0-fold (0.30 log units) away from the limit.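

Among the compounds shown here, this is the first reading on the aromatic ring, as all earlier steps altered the amide-type nitrogen: 4-fluorobenzyl to 4-methoxybenzyl, with the nitrogen left as it was, gives an at least 2.0-fold higher number from compound 1 to compound 4 (0.30 log units; that floor lies within the scatter). The change therefore brings no gain in this assay, and the read-out can only have stayed within the scatter or moved toward weaker inhibition, although the floor alone does not establish a real loss. Compound 4 gives a limit of the assay and not a number, so the full size of the step stays hidden, and this limit now recurs in a second compound: the limit of > 128000 nM in this assay, at which 2 of the 4 values shown sit.

The compounds shown leave open how far compound 4 really lies from compound 1, and whether any other group in this place, such as chloro, hydroxy, an amine or a carboxylic acid, would keep or improve the inhibition seen with fluoro. For the compounds shown here, they also leave open whether methoxy would have the same outcome on the isopropyl-bearing nitrogen of compound 2, the strongest number known so far.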